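Trimming a methoxy group from a trimethoxyphenyl chalcone-type pyrazole

The source may report more compounds than this note shows. Statements on the series, on what has been measured and on what is new or still open speak of the compounds shown alone.

Compound 1, `COc1cc(-c2cc(/C=C/C(=O)c3ccc(N)cc3)[nH]n2)cc(OC)c1OC`: 103%
Compound 2, `COc1ccc(-c2cc(/C=C/C(=O)c3ccc(OC)c(OC)c3)[nH]n2)cc1`: 94%
Compound 3, `COc1cc(-c2cc(/C=C/C(=O)c3ccc(Cl)c(Cl)c3)[nH]n2)cc(OC)c1OC`: 92%

Three compounds sharing a common core were measured in a functional assay on NCI-H322M cells (Homo sapiens) for cytotoxicity, read by sulforhodamine B assay, with a stated time of 48 h, tested at 0.1 uM; a higher number here means a weaker effect of the compound at the concentration tested, a lower number a stronger effect. Compound 1 has the highest of the three numbers; its nearest neighbour is compound 2, whose value of 94% lies within the scatter of it, while compound 3 sits furthest away. Going by the values given here, the one step between compounds that differ in a single place is a number 11 percentage points lower from compound 1 to compound 3 (beyond the scatter), a modest but real shift.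

The unmeasured compound 4, `COc1ccc(-c2cc(/C=C/C(=O)c3ccc(N)cc3)[nH]n2)cc1OC`, differs from compound 1 by hydrogen in place of methoxy on an aromatic carbon. Among the compounds with values here, no measured step touches that position: the only recorded step concerns the other end of the molecule, and compound 2, which also carries fewer methoxy groups on that ring, differs from compound 1 in more than one place and so shows only that its value stays within the scatter of compound 1. Within the data shown here, with no step bearing on the change, no shift beyond the scatter is expected in this assay, the expected step being a number 3 percentage points lower from compound 1 to compound 4 (within the scatter). Compound 4 is therefore estimated at 100%, within 88% to 112%.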

Compound 4, a percentage reported as activity, at one concentration (the size of the read-out at that concentration, not a potency): 102%
Compound 4: the middle estimate sits 2 percentage points below what was measured; the measured number falls inside the stated range.
By their numbers in this assay, from the lowest: compounds 3, 2, 4 and 1 (each within the scatter of the next, the first and the last beyond it).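

In this assay, going by these compounds alone, hydrogen in place of methoxy on an aromatic carbon gives a number 1 percentage points lower from compound 1 to compound 4 (within the scatter), the first reading of a single change on this ring, since the only earlier single-place step lay at the other end of the molecule. At this position, ortho to a methoxy group and meta to a large group, the methoxy can therefore be lost without a shift beyond the scatter, at the one concentration tested and with the 4-aminophenyl group in place. Nothing at hand explains this result or says what the methoxy group does here.

Going by these compounds, whether a hydroxyl group, an ethoxy group or a fluorine atom at this position would behave the same remains open. So does whether the same change would read alike at a higher concentration, or on a compound carrying the 3,4-dichlorophenyl group of compound 3.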